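Swapping an amide substituent on a dichlorophenyl ketone core

The source may report more compounds than this note shows. Statements on the series, on what has been measured and on what is new or still open speak of the compounds shown alone.

Compound 1 `C=C(CC)C(=O)c1ccc(OCC(=O)NCCO)c(Cl)c1Cl` carries a 2-hydroxyethyl group on an amide-type nitrogen. In a functional assay on CLL cells (Homo sapiens) for cytotoxicity, read by MTT assay, with a stated time of 48 h (on this read-out higher numbers stand for an effect only at larger amounts of compound and lower numbers for an effect already at smaller amounts), compound 1 gives only a limit, > 25000 nM, so its exact number is not known. Two measured relatives change the same amide substituent. Compound 2 `C=C(CC)C(=O)c1ccc(OCC(=O)Nc2ccc3nc[nH]c3c2)c(Cl)c1Cl` gives 3200 nM in this assay, and compound 3 `C=C(CC)C(=O)c1ccc(OCC(=O)NCO[N+](=O)[O-])c(Cl)c1Cl` gives 4100 nM; the step from compound 2 to compound 3 is a 1.3-fold higher number from compound 2 to compound 3 (0.11 log units; within the scatter). Against compound 1 these are an at least 7.8-fold lower number from compound 1 to compound 2 (0.89 log units; beyond the scatter) and an at least 6.0-fold lower number from compound 1 to compound 3 (0.78 log units; beyond the scatter), both beyond the scatter, though their true size is hidden because of the limit of > 25000 nM in this assay, at which 1 of the 3 values shown sits.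

Compound 4 `C=C(CC)C(=O)c1ccc(OCC(=O)Nc2ccc(C(C)=O)cc2)c(Cl)c1Cl` is the unmeasured case, differing from compound 1 by 4-acetylphenyl in place of 2-hydroxyethyl on an amide-type nitrogen. Like compound 2, it places an aromatic ring on the amide nitrogen. On the strength of the two measured steps, compound 4 is expected to land near compound 2 and compound 3, with an expected step of an at least 7.1-fold lower number from compound 1 to compound 4 (0.85 log units; beyond the scatter) in this assay. The estimate for compound 4 is therefore 3500 nM, within 1200 nM to 10000 nM.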

Compound 4, half-maximal effective concentration: 3900 nM
Compound 4: middle estimate off by 1.1-fold (0.05 log units), on the low side; the range from low to high includes it.
By their numbers in this assay, from the lowest: compounds 2, 4 and 3 (each within the scatter of the next). At a limit, above all of these: compound 1.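

With 4-acetylphenyl on the amide-type nitrogen, this assay shows an at least 6.4-fold lower number from compound 1 to compound 4 (0.80 log units; beyond the scatter), so a third, quite different group also parts from 2-hydroxyethyl. The replacements do not separate from one another, with a 1.1-fold lower number from compound 3 to compound 4 (0.02 log units; within the scatter) and a 1.2-fold higher number from compound 2 to compound 4 (0.09 log units; within the scatter), so at this position a ring of carbon only, 1H-benzimidazol-6-yl and (nitrooxy)methyl cannot be told apart in these values. How far compound 4 truly lies from compound 1 stays unknown, because the value of compound 1 is a limit: the limit of > 25000 nM in this assay, at which 1 of the 4 values shown sits.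

The compounds shown leave open whether the difference rests on the hydroxyl of compound 1, which a plain ethyl chain or a 2-aminoethyl group would test. They also leave open whether an unsubstituted phenyl ring would fall with compound 2, compound 3 and compound 4.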